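The source may hold more compounds than are shown below. What is called first, only, known or untested is meant among the compounds shown, and "the series" means these compounds.

Compound 1, `CC(N)C[Se]c1ccc(F)cc1`: 13400 nM
Compound 2, `Cc1ccc([Se]CC(C)N)cc1`: 36500 nM

Both compounds were tested in an assay on isolated protein for inhibition of Amine oxidase [flavin-containing] B (Homo sapiens), read by fluorescence and spectrophotometry; a higher number here means a weaker inhibitor, a lower number a stronger inhibitor. For the measured compounds named here, of the two numbers, compound 2 stands highest, with compound 1 as its only neighbour, and the single measured step between them is a 2.7-fold higher number from compound 1 to compound 2 (0.44 log units; beyond the scatter), a modest one. Compound 3, `CC(N)C[Se]c1ccc(N(C)C)cc1`, has not been measured. It differs from compound 2 by dimethylamino in place of methyl on an aromatic carbon. Going by the values given here, no measured step exchanges a methyl for a dimethylamino group, so the only guide is that swapping one small group on the same aromatic carbon gave a 2.7-fold higher number from compound 1 to compound 2 (0.44 log units; beyond the scatter). A shift of comparable, modest size in this assay is plausible, in either direction, and nothing beyond the scatter can be foreseen with confidence. Compound 3 is therefore estimated at 45000 nM, with a range from 13000 nM to 150000 nM. This estimate implies an expected step of a 1.2-fold higher number from compound 2 to compound 3 (0.09 log units; within the scatter).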

Compound 3, half-maximal inhibitory concentration: 21300 nM
Beside the measured number, compound 3's estimate is 2.1-fold (0.32 log units) above it; measured number inside the range.
By their numbers in this assay, from the lowest: compounds 1, 3 and 2 (each within the scatter of the next, the first and the last beyond it).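

In this assay, dimethylamino, with 3 heavy atoms and 1 hydrogen-bond acceptor, replaces methyl, with 1 heavy atom and no acceptor, giving a 1.7-fold lower number from compound 2 to compound 3 (0.23 log units; within the scatter); set against fluoro, the same group gives a 1.6-fold higher number from compound 1 to compound 3 (0.20 log units; within the scatter). This aromatic carbon therefore takes the larger, nitrogen-bearing group with no step beyond the scatter from either neighbour, so compound 3 cannot be told apart from compound 1 or compound 2, even though those two differ beyond the scatter. Nothing available explains why these numbers fall as they do.

On these data alone, whether a carboxylic acid or a trifluoromethyl group on this carbon would move the number beyond the scatter remains open. So does whether a longer chain on the shared core's amine would change the picture.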